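Sulfur substituent swap from compound 3 to compound 4

A few compounds are considered here, and "the series" means these few. Any claim that something is new, unique, unknown or untested is made for them only; others in the source may bear on it.

Values in an ADME assay on BCBL1 cells (Homo sapiens) for cytotoxicity, with a stated time of 7 days (a higher number here means that more compound is tolerated, a lower number that less compound is tolerated), as they stand so far:
compound 1 (`CC(C)CSc1nc(N)nc2c1ncn2/C=C1/CC1(CO)CO`) gives > 20000 nM as a limit
compound 2 (`Nc1nc(N2CCCC2)c2ncn(/C=C3/CC3(CO)CO)c2n1`) gives > 20000 nM as a limit
compound 3 (`CC(C)Sc1nc(N)nc2c1ncn2/C=C1/CC1(CO)CO`) gives > 20000 nM as a limit
compound 4 (`Nc1nc(SC2CCCC2)c2ncn(/C=C3/CC3(CO)CO)c2n1`) has no measurement yet

Compound 3 gives > 20000 nM as a limit and not as a number. Going by the values given here, the same holds across the set, with the limit of > 20000 nM in this assay, at which 3 of the 3 values shown sit, as the only reading available. The change to compound 4 is cyclopentyl in place of isopropyl on a sulfur in one place, cyclopentyl in place of isopropyl on a sulfur.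

Among the compounds with values here, three measured steps bear on this position. The nearest is a step that the two limits leave unreadable from compound 1 to compound 3 and it also exchanges one group on the sulfur for another. The other two are a step that the two limits leave unreadable from compound 1 to compound 2 and a step that the two limits leave unreadable from compound 2 to compound 3 and both replace the whole sulfanyl group. None of them has a readable size, so they offer no direction. On this evidence, no step beyond the usual scatter is expected in this assay and a further limit is the likeliest report. The expected outcome is a number no higher from compound 3 to compound 4 (the limit leaves the size open) as a working figure only. For compound 4 the estimate is 20000 nM with an expected range from 7000 nM to 40000 nM in this measurement.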

Compound 4, half-maximal cytotoxic concentration: > 20000 nM
Compound 4: only a limit was reported; the forecaster's own chance of this, stated with the estimate: 70%; the middle value sits exactly at the limit.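

In this assay, the steps linking compound 4 to compound 1, compound 2 and compound 3 cannot be read, as every reading is a limit and not a number: the limit of > 20000 nM in this assay, at which 4 of the 4 values shown sit.

The compounds shown leave open where the half-maximal cytotoxic concentration of each compound lies, and whether isobutylsulfanyl, isopropylsulfanyl, cyclopentylsulfanyl and pyrrolidin-1-yl differ at all in this read-out.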